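Swapping fluoro for chloro on two related cores

This account rests on a few compounds, and the source may have more. Where it says the series, first, only, none or still open, it means among the compounds named here.

Compound 1 `CS(=O)(=O)C[C@H]1O[C@@H](n2cnc3c(N)nc(F)nc32)[C@H](O)[C@@H]1O` gives 5000 nM in an ADME assay on L6 cells (Rattus norvegicus) for inhibition, read by resazurin assay, with a stated time of 72 h; a lower number here means a stronger inhibitor, a higher number a weaker inhibitor.
Compound 2 `CS(=O)(=O)C[C@H]1O[C@@H](n2cnc3c(N)nc(Cl)nc32)[C@H](O)[C@@H]1O` gives 156000 nM in this assay.
Compound 3 `CC(=O)O[C@@H]1[C@H](OC(C)=O)[C@@H](CI)O[C@H]1n1cnc2c(N)nc(F)nc21` gives 6300 nM in this assay.

Compounds 1 and 2 share one core and differ only by chloro in place of fluoro on an aromatic carbon. That single exchange made a 31-fold higher number from compound 1 to compound 2 (1.49 log units; beyond the scatter), so compound 2 is by far the weakest inhibitor of the three. Compound 3 is built on a different core; the difference between the two cores is not broken down here. Its value stands close to that of compound 1 and far from that of compound 2.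

Compound 4 `CC(=O)O[C@@H]1[C@H](OC(C)=O)[C@@H](CI)O[C@H]1n1cnc2c(N)nc(Cl)nc21` has not yet been measured in this assay. It differs from compound 3 by chloro in place of fluoro on an aromatic carbon, the same change, at the same place, as from compound 1 to compound 2. Compound 4 is therefore expected to be a much weaker inhibitor than compound 3, with a step of about a 30-fold higher number from compound 3 to compound 4 (1.48 log units; beyond the scatter) expected, because of a 31-fold higher number from compound 1 to compound 2 (1.49 log units; beyond the scatter) on the other core. Some uncertainty remains, since the change has been seen only once, on a different core. The estimate for compound 4 is 190000 nM, likely falling between 60000 nM and 600000 nM.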

Compound 4, half-maximal inhibitory concentration: 86000 nM
The estimate for compound 4 lay 2.2-fold (0.34 log units) above the measured number, within the range that was stated.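

Chloro in place of fluoro on an aromatic carbon again gave a much weaker inhibitor in this assay, with a 14-fold higher number from compound 3 to compound 4 (1.14 log units; beyond the scatter). Set beside the earlier step, the change points the same way on both cores, and the two sizes agree within the usual scatter: the same change on two cores in this assay, a 31-fold higher number (1.49 log units; beyond the scatter) from compound 1 to compound 2 and a 14-fold higher number (1.14 log units; beyond the scatter) from compound 3 to compound 4, 2.3-fold (0.36 log units) apart, within the scatter of two such steps. So in these two pairs the effect of the exchange carried over from one core to the other, but two pairs cannot show that it would hold on a further core, and these numbers alone do not explain why the chloro compounds are weaker.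

The compounds shown carry only fluoro or chloro at this aromatic carbon, so it remains open how a bromo group, a methyl group or an amine in the same place would compare. Also open, as far as these compounds go, is how the separate differences between the two cores, such as acetate esters in place of free hydroxyl groups, affect the number.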